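This account rests on a few compounds, and the source may have more. Where it says the series, first, only, none or still open, it means among the compounds named here.

Measured compounds:
compound 1, `O=C(O)COc1ccc(NC(=O)C(=O)Nc2ccccc2)cc1F`: 9.78%
compound 2, `Cc1ccc(NC(=O)C(=O)Nc2ccc(OCC(=O)O)c(F)c2)cc1`: 11.4%
compound 3, `Cc1cccc(NC(=O)C(=O)Nc2ccc(OCC(=O)O)c(F)c2)c1`: 17.7%

In a functional assay on CHO cells for agonist activity at Free fatty acid receptor 1 (Homo sapiens), read by FLIPR, tested at 100 nM (on this read-out lower numbers stand for a weaker effect and higher numbers for a stronger effect at the one concentration tested), compound 1 gives 9.78%, the lowest of the three numbers recorded, but both of its gaps to the other two lie within the scatter: a number 1.6 percentage points higher from compound 1 to compound 2 (within the scatter) and a number 7.9 percentage points higher from compound 1 to compound 3 (within the scatter). Likewise a number 6.3 percentage points higher from compound 2 to compound 3 (within the scatter), so the three measured compounds cannot be told apart on this read-out.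

Compound 4, `O=C(O)COc1ccc(NC(=O)C(=O)Nc2ccccc2Cl)cc1F`, is the next member to be measured. Its difference from compound 1 is chloro in place of hydrogen on an aromatic carbon. The two steps that bear on it are the ones from compound 1 to compound 2 and to compound 3, each an added substituent on the same ring of the shared core of compound 1, and both stayed within the scatter. Among the compounds with values here, the change to compound 4 is of the same kind, a single added substituent on that ring, though of a different group, and no measured step tells how chloro itself behaves here. On this basis no step beyond the scatter is expected in this assay in either direction; the estimated step is a number 2.2 percentage points higher from compound 1 to compound 4 (within the scatter).

Compound 4 is therefore expected to give about 12%, with a likely range from 3% to 24%.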

Compound 4, a percentage reported as activity, at one concentration (the size of the read-out at that concentration, not a potency): 10.2%
The estimate for compound 4 lay 1.8 percentage points above the measured number, within the range that was stated.
By their numbers in this assay, from the lowest: compounds 1, 4, 2 and 3 (each within the scatter of the next).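

With chloro on an aromatic carbon ortho to a large group, compound 4 extends the series to a third ring position and to a first halogen in this assay, and the change leaves the read-out flat, with a number 0.4 percentage points higher from compound 1 to compound 4 (within the scatter). Direct exchange of the substituted phenyl groups also separates nothing, with 2-chlorophenyl in place of 3-methylphenyl giving a number 7.5 percentage points lower from compound 3 to compound 4 (within the scatter) and 2-chlorophenyl in place of 4-methylphenyl giving a number 1.2 percentage points lower from compound 2 to compound 4 (within the scatter), so the 2-chlorophenyl, 3-methylphenyl and 4-methylphenyl compounds and the unsubstituted phenyl compound all remain indistinguishable on this read-out. No supporting data bear on why this position tolerates chloro without a visible change.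

Group and position remain confounded across these compounds: a 2-methylphenyl, 3-chlorophenyl or 4-chlorophenyl member would be needed to compare methyl and chloro at a single position. Also open, on these data alone, is whether any substituent on this ring can produce a step beyond the scatter, for example an amine, a methoxy group, a carboxylic acid or a longer alkyl chain.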